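Expected Cytotoxicity of a Methylpyrazole Analogue

The source may report more compounds than this note shows. Statements on the series, on what has been measured and on what is new or still open speak of the compounds shown alone.

Compound 1 `O=c1nc(-c2ccccc2)c2cc(-c3cncnc3)ccc2[nH]1` and compound 2 `O=c1nc(-c2ccccc2)c2cc(-c3cc[nH]n3)ccc2[nH]1` share one core and differ only in the group attached to the carbon-only ring of that core. In an ADME assay on THP-1 cells (Homo sapiens) for cytotoxicity, read by MTT assay, with a stated time of 72 h (on this read-out lower numbers stand for an effect already at smaller amounts and higher numbers for an effect only at larger amounts of compound), compound 1 reaches only the limit > 50000 nM, so no number is known for it. In this assay compound 2 likewise reaches only the limit > 50000 nM. The step that the two limits leave unreadable from compound 1 to compound 2 is therefore unreadable in size and direction, and compound 2 stands exactly where both measured values stand, at the limit of > 50000 nM in this assay, at which 2 of the 2 values shown sit. Compound 3 `Cn1cc(-c2ccc3[nH]c(=O)nc(-c4ccccc4)c3c2)cn1` has not yet been measured; it differs from compound 2 by 1-methyl-1H-pyrazol-4-yl in place of 1H-pyrazol-3-yl on an aromatic carbon. For the measured compounds named here, only one measured step bears on this change, and it shows merely that two different five-membered aromatic groups at the same place both left the cell viability read-out at the limit. The step of a number no higher from compound 2 to compound 3 (the limit leaves the size open) is therefore expected to be none beyond the scatter. Compound 3 is expected to give 50000 nM in this assay, within a range from 30000 nM to 100000 nM, most likely reported once more as a limit rather than a number.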

Compound 3, half-maximal effective concentration: > 50000 nM
Compound 3 gave a limit, no number (the forecaster's own chance of this, stated with the estimate: 85%); the middle value sits exactly at the limit.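

Compound 3, like compound 1 and compound 2, gives only a limit in this assay, so its steps to those two compounds cannot be read in size or direction. The compounds shown leave open at which concentration any of them would reach the half-maximal effect, and whether their three groups differ at all in this read-out.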